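Pyridin-3-yl for pyridin-4-yl: forecast for compound 4

A few compounds are considered here, and "the series" means these few. Any claim that something is new, unique, unknown or untested is made for them only; others in the source may bear on it.

Measured so far in a functional assay (cardiac atrium) for agonist activity, with Cavia porcellus as the target; on this read-out higher numbers stand for an effect only at larger amounts of compound and lower numbers for an effect already at smaller amounts:
compound 1 `CCO/C(O)=C1\C(C)=NC(C)=C([N+](=O)[O-])C1c1ccncc1` gives 6460 nM
compound 2 `CC1=NC(C)=C([N+](=O)[O-])C(c2ccncc2)/C1=C(\O)OC(C)(C)C` gives 2820 nM
compound 3 `CC1=NC(C)=C([N+](=O)[O-])C(c2ccncc2)/C1=C(\O)OC(C)C` gives 8050 nM

Compound 2 stands at the lowest number of the three in this assay. Both of its steps lie beyond the scatter: a 2.3-fold lower number from compound 1 to compound 2 (0.36 log units; beyond the scatter) and a 2.9-fold higher number from compound 2 to compound 3 (0.46 log units; beyond the scatter), so compound 2 is the most potent compound measured here. Compound 1 and compound 3 cannot be ordered, since a 1.2-fold higher number from compound 1 to compound 3 (0.10 log units; within the scatter).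

Compound 4 `CC1=NC(C)=C([N+](=O)[O-])C(c2cccnc2)/C1=C(\O)OC(C)(C)C` keeps the ester of compound 2 and differs from it in one place only: pyridin-3-yl in place of pyridin-4-yl on a saturated ring carbon. The three measured steps all concern the ester group on the oxygen of the unsaturated carbon; none of them involves the aromatic ring on the saturated ring carbon. For the measured compounds named here, there is therefore no precedent in this set for the change from compound 2 to compound 4, and the expectation can only be that the number stays near that of compound 2, with no step beyond the scatter, that is an expected 1.1-fold lower number from compound 2 to compound 4 (0.05 log units; within the scatter). The uncertainty is wide for lack of any comparable step. Compound 4 is estimated at 2500 nM in this assay, with a range from 800 nM to 8000 nM.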

Compound 4, half-maximal effective concentration: 14600 nM
The estimate for compound 4 lay 5.8-fold (0.77 log units) below the measured number; measured number outside the range, above it.
By their numbers in this assay, from the lowest: compound 2; then compounds 1, 3 and 4 (each within the scatter of the next, the first and the last beyond it).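

In this assay, for the compounds shown here, the aromatic ring on the saturated ring carbon, next to the ring atom that bears a nitro group, proves to be a place where the number responds: pyridin-3-yl in place of pyridin-4-yl gives a 5.2-fold higher number from compound 2 to compound 4 (0.71 log units; beyond the scatter), a first reading of this position, as the earlier steps all concerned the ester group. The two groups match in every count printed for them, with the same atoms joined differently, so a change in where the nitrogen sits within the aromatic ring is enough to produce a step beyond the scatter while the tert-butyl ester stays the same. Nothing available here explains why the pyridin-3-yl compound needs larger amounts for an effect.

Going by these compounds, all that is known of this position rests on this single pair with the tert-butyl ester, so whether the step carries over to the esters of compound 1 and compound 3 remains open. Also open, on these data alone, is how a pyridin-2-yl or a phenyl ring on the same saturated ring carbon would compare with the pyridin-4-yl of compound 2.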